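The source may hold more compounds than are shown below. What is called first, only, known or untested is meant among the compounds shown, and "the series" means these compounds.

Compound 3 `C[C@H](NC(=O)Nc1cccc(F)c1)c1ccccc1` is the point of departure here, with compound 1 `Cc1cccc(NC(=O)N[C@@H](C)c2ccccc2)c1` and compound 2 `C[C@H](NC(=O)Nc1cccc(C(F)(F)F)c1)c1ccccc1` as its closest measured companions. In an ADME assay on the whole organism with Oryza sativa as the target, tested at 0.1 uM (on this read-out higher numbers stand for a weaker effect at the one concentration tested and lower numbers for a stronger effect), compound 3 gives 97%; in this assay compound 1 gives 99% and compound 2 gives 94%. The three numbers sit close together: a number 2 percentage points lower from compound 1 to compound 3 (within the scatter), a number 3 percentage points higher from compound 2 to compound 3 (within the scatter), and a number 5 percentage points lower from compound 1 to compound 2 (within the scatter). Compound 4 `C[C@H](NC(=O)Nc1cccc(Cl)c1)c1ccccc1` differs from compound 3 by chloro in place of fluoro on an aromatic carbon. The bearing steps, which exchange methyl or trifluoromethyl for fluoro at the same position, all stay within the scatter, so compound 4 is expected to show no step beyond the scatter, a number 1 percentage points lower from compound 3 to compound 4 (within the scatter). The value for compound 4 in this assay is thus estimated at 96%, within 89% to 100%.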

Compound 4, a percentage reported as activity, at one concentration (the size of the read-out at that concentration, not a potency): 103%
Compound 4: the middle estimate sits 7 percentage points below what was measured; the measured number lies above the stated range.
By their numbers in this assay, from the lowest: compounds 2, 3, 1 and 4 (each within the scatter of the next).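

Chloro in place of fluoro gives a number 6 percentage points higher from compound 3 to compound 4 (within the scatter), chloro in place of trifluoromethyl gives a number 9 percentage points higher from compound 2 to compound 4 (within the scatter), and chloro in place of methyl gives a number 4 percentage points higher from compound 1 to compound 4 (within the scatter) in this assay at this position. A second halogen therefore joins methyl, trifluoromethyl and fluoro as a fourth group whose steps to all the others stay within the scatter. No evidence at hand bears on this result. As far as these compounds go, it remains open whether an amine, a carboxylic acid or a methoxy group on this aromatic carbon would give a step beyond the scatter, and whether these four compounds would stay together at another concentration.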